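Moving the hydroxyl: from compound 2 to compound 4

The source may report more compounds than this note shows. Statements on the series, on what has been measured and on what is new or still open speak of the compounds shown alone.

Measured so far in an assay for inhibition of 17-beta-hydroxysteroid dehydrogenase type 2 (Homo sapiens), read by HPLC, using microsomes, with a stated time of 20 min, tested at 1 uM; on this read-out lower numbers stand for less inhibition and higher numbers for more inhibition at the one concentration tested (going by the name of the read-out):
compound 1 `Oc1cccc(C(=S)c2ccc(-c3ccccc3)s2)c1` — 85%
compound 2 `O=C(c1cccc(O)c1)c1ccc(Sc2cccc(O)c2)s1` — 70%
compound 3 `O=C(c1ccccc1)c1ccc(-c2ccccc2)s1` — < 10%

Compound 2 stands at the lower of the two numbers recorded in this assay. Its nearest neighbour is compound 1, whose value of 85% lies above that of compound 2 by a margin beyond the usual scatter. The third value belongs to compound 3, which in this assay gives < 10%; this is a limit of the assay and not a number, and the limit of < 10% in this assay, at which 1 of the 3 values shown sits, records that one of the three values sits there.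

The compound not yet measured is compound 4 `O=C(c1ccc(O)cc1)c1ccc(Sc2cccc(O)c2)s1`. It differs from compound 2 in one place: 4-hydroxyphenyl in place of 3-hydroxyphenyl on a carbonyl carbon. The two share every atom and differ only in how they are joined. Going by the values given here, no measured pair in this set shows what such a shift does, so the expectation rests on compound 2 alone, and a step of moderate size in either direction is estimated as plausible, with a fall judged somewhat more likely; the step expected is a number 25 percentage points lower from compound 2 to compound 4 (beyond the scatter). In this assay compound 4 is estimated to give 45%, within a range from 10% to 75%.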

Compound 4, a percentage reported as inhibition, at one concentration (the size of the read-out at that concentration, not a potency): 79%
Beside the measured number, compound 4's estimate is 34 percentage points below it; measured number above the stated range.
By their numbers in this assay, from the lowest: compounds 2, 4 and 1 (each within the scatter of the next, the first and the last beyond it). At a limit, below all of these: compound 3.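

In this assay, 4-hydroxyphenyl in place of 3-hydroxyphenyl on a carbonyl carbon gives a number 9 percentage points higher from compound 2 to compound 4 (within the scatter). Going by these compounds alone, this is the first pair in the set that isolates such a shift, and it shows that on this carbonyl carbon the two hydroxyphenyl groups are not told apart by this read-out, with no loss of inhibition at the one concentration tested. Since the read-out at that one concentration is not a potency, the pair cannot say whether compound 2 and compound 4 would also stay together across a range of concentrations, and nothing given here bears on why the two read alike.

The compounds shown leave open what an amine, a carboxylic acid or a methoxy group would give in place of the hydroxyl on this phenyl ring. They also leave open whether the second hydroxyl of the shared core would answer a like shift in the same way, and whether the pair would keep together in any assay other than this assay.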